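A few compounds are considered here, and "the series" means these few. Any claim that something is new, unique, unknown or untested is made for them only; others in the source may bear on it.

Working notes on the series.

For the measured compounds named here, compound 2 `COc1ccc(-c2ccc(Oc3ccccc3C)c(NC(=O)Nc3ccc(C)cc3)c2)cc1C(=O)O` is the weaker of the two compounds measured so far in an assay on HeLa cells for inhibition of Indoleamine 2,3-dioxygenase 1 (Homo sapiens), with a stated time of 20 h; on this read-out higher numbers stand for weaker inhibition and lower numbers for stronger inhibition: compound 2 gives 840 nM, while compound 1 `CCc1ccccc1Oc1ccc(-c2ccc(OC)c(C(=O)O)c2)cc1NC(=O)Nc1ccc(C)cc1` gives 540 nM. Going by the values given here, the only step so far, a 1.6-fold higher number from compound 1 to compound 2 (0.19 log units; within the scatter), exchanges ethyl for methyl on the phenoxy ring and does not move the number beyond the scatter, so compound 2 stands at the high end of a pair that is effectively indistinguishable.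

Compound 3 `COc1ccc(-c2ccc(Oc3ccccc3C#N)c(NC(=O)Nc3ccc(C)cc3)c2)cc1C(=O)O` differs from compound 2 in one place: cyano in place of methyl on an aromatic carbon. Among the compounds with values here, no measured step in this set exchanges a methyl for a cyano, so the only step that bears on the position is the ethyl-to-methyl step, a 1.6-fold higher number from compound 1 to compound 2 (0.19 log units; within the scatter), which shows that modest changes at this position on the phenoxy ring have so far stayed within the scatter.

On that basis compound 3 is expected to land near compound 2, with a 1.1-fold higher number from compound 2 to compound 3 (0.03 log units; within the scatter) estimated to stay inside the scatter. The estimate for compound 3 in this assay is 900 nM, with a range from 300 nM to 2700 nM.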

Compound 3, half-maximal inhibitory concentration: 6000 nM
Compound 3: middle estimate off by 6.7-fold (0.82 log units), on the low side; the whole stated range lies below it.
By their numbers in this assay, from the lowest: compounds 1 and 2 (each within the scatter of the next); then compound 3.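

The exchange of 2-methylphenoxy for 2-cyanophenoxy is the only change shown at this place in this assay that passes beyond the scatter, with a 7.1-fold higher number from compound 2 to compound 3 (0.85 log units; beyond the scatter) and, for cyano against ethyl, with an 11-fold higher number from compound 1 to compound 3 (1.05 log units; beyond the scatter). The position therefore does not accept every small group alike: methyl and ethyl lie within the scatter of each other, while cyano, which brings a triple bond and a hydrogen-bond acceptor that methyl lacks, gives clearly weaker inhibition. Nothing at hand bears on why the number rises at this position.

The compounds shown leave open whether the higher number belongs to cyano alone or also appears with other groups that are not alkyl chains, such as chloro or methoxy, and an unsubstituted ring would show how methyl, ethyl and cyano each compare with hydrogen at this place. They also leave open whether a longer chain, such as propyl, stays within the scatter of ethyl, or whether the tolerance for alkyl groups ends there.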